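The compounds below may be only part of what the source reports. "The series", "measured", "known", "first", "only" and "open" are said of these compounds alone.

The measured compounds:
compound 1, `COc1ccc(/C=C/C(=O)Nc2cc(C(=O)c3cc(OC)c(OC)c(OC)c3)ccc2OC)cc1`, 11100 nM
compound 2, `C#CCOc1cccc(/C=C/C(=O)Nc2cc(C(=O)c3cc(OC)c(OC)c(OC)c3)ccc2OC)c1`, 13100 nM
compound 3, `COc1cc(/C=C/C(=O)Nc2cc(C(=O)c3cc(OC)c(OC)c(OC)c3)ccc2OC)ccc1F`, 14100 nM

All three were tested in a functional assay on PC-3 cells (Homo sapiens) for cytotoxicity, read by MTT assay, with a stated time of 72 h; on this read-out higher numbers stand for weaker inhibition and lower numbers for stronger inhibition. Compound 1 gives the lowest of the three numbers in this assay, yet the steps of a 1.2-fold higher number from compound 1 to compound 2 (0.07 log units; within the scatter) and a 1.3-fold higher number from compound 1 to compound 3 (0.10 log units; within the scatter) both lie within the scatter, as does a 1.1-fold higher number from compound 2 to compound 3 (0.03 log units; within the scatter), so none of the three can be called the strongest or the weakest.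

Compound 4, `COc1ccc(/C=C/C(=O)Nc2cc(C(=O)c3cc(OC)c(OC)c(OC)c3)cc(OC)c2OC)cc1`, has not yet been measured. It differs from compound 1 by methoxy in place of hydrogen on an aromatic carbon. This change sits on the central ring of the shared core, whereas every measured step alters the aryl group at the end of the double-bonded chain. Within the data shown here, none of the measured steps therefore bears directly on it; all they show is that varying the distant aryl group left the number within the scatter each time. With nothing pointing in either direction, compound 4 is expected to sit close to compound 1. The step of a 1.0-fold lower number from compound 1 to compound 4 (0.00 log units; within the scatter) is expected to stay within the scatter, though the absence of any comparable change leaves the range wide. The estimate for compound 4 in this assay is 11000 nM, from 4000 nM to 30000 nM.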

Compound 4, half-maximal inhibitory concentration: 6300 nM
Beside the measured number, compound 4's estimate is 1.7-fold (0.24 log units) above it; low and high end bracket the measured number.
By their numbers in this assay, from the lowest: compounds 4, 1, 2 and 3 (each within the scatter of the next, the first and the last beyond it).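

Methoxy in place of hydrogen, on an aromatic carbon ortho to a methoxy group and meta to two large groups, gives a 1.8-fold lower number from compound 1 to compound 4 (0.25 log units; within the scatter) in this assay. This is the first step shown that alters the shared core rather than the aryl group at the end of the double-bonded chain, and it too stays within the scatter, so on this single pair the position accepts a methoxy with its 2 heavy atoms without a difference that can be told from repeated measurement. No measured property of these compounds is available to account for the size of this step.

The compounds shown leave open whether other groups on this aromatic carbon, such as a hydroxyl, an amine or a longer alkoxy chain, would also stay within the scatter of compound 1. They also leave open whether the same methoxy would give a step of similar size with the 3-(propargyloxy)phenyl of compound 2 or the 4-fluoro-3-methoxyphenyl of compound 3 at the end of the chain.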